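Swapping One Fluorinated Phenyl for Another on the Saturated Carbon

A few compounds are considered here, and "the series" means these few. Any claim that something is new, unique, unknown or untested is made for them only; others in the source may bear on it.

Among the three compounds measured so far, compound 2 `COc1cc(C2=NN(C(C)=O)C(c3ccccc3C(F)(F)F)O2)cc(OC)c1OC` gives the highest number in a functional assay on BGC-823 cells (Homo sapiens) for antiproliferative activity, read by MTT assay, tested at 5 uM (a higher number here means a stronger effect of the compound at the concentration tested, a lower number a weaker effect), namely 34.8%. Compound 1 `COc1cc(C2=NN(C(C)=O)C(c3cc(OC)c(OC)c(OC)c3)O2)cc(OC)c1OC` gives -1.4%, and compound 3 `COc1ccc(OC)c(/C=N/NC(=O)c2cc(OC)c(OC)c(OC)c2)c1` gives 10.1%; both of these lie beyond the scatter below compound 2. Compound 4 `COc1cc(C2=NN(C(C)=O)C(c3ccc(F)c(F)c3)O2)cc(OC)c1OC` has not yet been measured. It differs from compound 2 in a single place: 3,4-difluorophenyl in place of 2-(trifluoromethyl)phenyl on a saturated ring carbon. Among the measured compounds shown here, no measured pair in this set follows a change of this kind, so the size of the step is uncertain. A step of a number 9.8 percentage points lower from compound 2 to compound 4 (within the scatter) is expected, most likely a moderate decrease, though a result within the scatter cannot be excluded. Compound 4 is therefore estimated at 25%, within a range from 5% to 45%.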

Compound 4, a percentage reported as inhibition, at one concentration (the size of the read-out at that concentration, not a potency): 21.6%
Beside the measured number, compound 4's estimate is 3.4 percentage points above it; the range from low to high includes it.
By their numbers in this assay, from the lowest: compound 1; then compound 3; then compound 4; then compound 2.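

In this assay, putting 3,4-difluorophenyl in place of 2-(trifluoromethyl)phenyl on the saturated ring carbon gives a step of a number 13.2 percentage points lower from compound 2 to compound 4 (beyond the scatter). So this position responds even when one fluorinated phenyl replaces another, and the effect does not vanish, since compound 4 still gives 21.6%. No measurement shown here accounts for the difference.

The compounds shown do not separate the loss of the trifluoromethyl group from the change in where fluorine sits on the phenyl ring. As far as these compounds go, how a plain phenyl, or a phenyl carrying a nitrile or an amine, would compare at this carbon also remains open.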